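The source may report more compounds than this note shows. Statements on the series, on what has been measured and on what is new or still open speak of the compounds shown alone.

Compound 1 `COc1cccc(OC)c1N1C(=O)CSC1c1cccc(C(=O)NCCCCc2ccccc2)c1`: > 1000 nM
Compound 2 `C#Cc1cc(C(=O)NCCCCc2ccccc2)cc(C2SCC(=O)N2c2ccccc2OC)c1`: 40.8 nM
Compound 3 `O=C(NCCCCc1ccccc1)c1cc(F)cc(C2SCC(=O)N2c2ccccn2)c1`: 14.2 nM

Of the compounds shown here, three sharing one core have been tested in a functional assay on HOS-TE85 cells (Homo sapiens) for inhibition, read by CCK-8 assay, with a stated time of 72 h; on this read-out higher numbers stand for weaker inhibition and lower numbers for stronger inhibition. For compound 1 the assay returns only a limit, > 1000 nM, not a number; it sits at the limit described by the limit of > 1000 nM in this assay, at which 1 of the 3 values shown sits. Compound 2 gives 40.8 nM in this assay, and compound 3 gives 14.2 nM. Compound 1 thus stands apart from the other two, which both report measured numbers, while no step between any pair of these compounds has been worked out, since no two of them differ in only one place.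

The compound still to be measured is compound 4 `O=C(NCCCCc1ccccc1)c1cccc(C2SCC(=O)N2c2ccccc2)c1`. Against compound 1 the change is phenyl in place of 2,6-dimethoxyphenyl on an amide-type nitrogen in a ring. The account follows this single change from compound 1 to compound 4.

Because compound 1 returns only the limit > 1000 nM, the step can only be expected in one direction: any measured number for compound 4 would mean stronger inhibition, and the step from compound 1 to compound 4 is expected to be an at least 8.3-fold lower number from compound 1 to compound 4 (0.92 log units; beyond the scatter). This core can reach measured numbers in this assay: compound 2 reaches 40.8 nM, and compound 3 reaches 14.2 nM, though both of them differ from compound 4 in more than one place. For compound 4 the estimate in this assay is 120 nM, with a range from 25 nM to 1000 nM.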

Compound 4, half-maximal inhibitory concentration: 15.9 nM
The estimate for compound 4 lay 7.5-fold (0.88 log units) above the measured number; the whole stated range lies above it.
By their numbers in this assay, from the lowest: compounds 3 and 4 (each within the scatter of the next); then compound 2. At a limit, above all of these: compound 1.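

In this assay, for the compounds shown here, phenyl in place of 2,6-dimethoxyphenyl on the amide-type nitrogen in a ring of the shared core gives an at least 62-fold lower number from compound 1 to compound 4 (1.79 log units; beyond the scatter), the first step in this set that changes a single place. Compound 2 and compound 3 had shown that the core can reach measured numbers, but each differs from compound 1 in more than one place, so neither could tie the limit of compound 1 to this position; the present pair does, and losing the two methoxy groups is the only change needed to obtain a measured number. Compound 1 carries a limit and not a number, so the step marks only the smallest change consistent with the data, and its true size stays unknown: the limit of > 1000 nM in this assay, at which 1 of the 4 values shown sits.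

The compounds shown leave open whether a single methoxy group on this phenyl, with the rest of compound 4 unchanged, would read like compound 4 or like compound 1. They also leave open how this assay would respond to a benzyl group at this nitrogen, or to a chlorine atom on the phenyl.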